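Shared core series: removing the nitro group

A few compounds are considered here, and "the series" means these few. Any claim that something is new, unique, unknown or untested is made for them only; others in the source may bear on it.

Compound 1 `O=[N+]([O-])c1cccc(CSc2nnc(-c3ccc4c(c3)OCCO4)o2)c1` gives 30100 nM in a functional assay on SW 1116 cells (Homo sapiens) for antiproliferative activity, read by MTT assay, with a stated time of 48 h (a higher number here means a weaker inhibitor, a lower number a stronger inhibitor), and sits second highest of the three measured numbers, within the scatter of compound 3 `Cc1ccc(CSc2nnc(-c3ccc4c(c3)OCCO4)o2)cc1` at 32500 nM and of compound 2 `Cc1ccccc1CSc1nnc(-c2ccc3c(c2)OCCO3)o1` at 23900 nM. For the measured compounds named here, the only single-point step among the measured compounds, a 1.4-fold higher number from compound 2 to compound 3 (0.13 log units; within the scatter), lies within the scatter. Compound 4 `c1ccc(CSc2nnc(-c3ccc4c(c3)OCCO4)o2)cc1` differs from compound 1 by hydrogen in place of nitro on an aromatic carbon. Going by the values given here, no measured step removes a nitro group, so the change has no direct precedent; the three measured compounds, with varied ring substitution, all cluster together, and the expected step of a 1.1-fold lower number from compound 1 to compound 4 (0.03 log units; within the scatter) is therefore no change beyond the scatter. Compound 4 is estimated at 28000 nM, with a range of 14000 nM to 56000 nM.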

Compound 4, half-maximal inhibitory concentration: 31500 nM
Compound 4: the middle estimate sits 1.1-fold (0.05 log units) below what was measured, within the range that was stated.
By their numbers in this assay, from the lowest: compounds 2, 1, 4 and 3 (each within the scatter of the next).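

In this assay, hydrogen in place of nitro on an aromatic carbon leaves the number within the scatter (a 1.0-fold higher number from compound 1 to compound 4 (0.02 log units; within the scatter)). Hydrogen in place of methyl also stays within the scatter (a 1.0-fold lower number from compound 3 to compound 4 (0.01 log units; within the scatter); a 1.3-fold higher number from compound 2 to compound 4 (0.12 log units; within the scatter)), so the ring without a substituent does not separate from the methyl or nitro compounds. No evidence at hand bears on this result.

On these data alone, whether an amine, a carboxylic acid or a longer chain on this ring would give a step beyond the scatter remains open. So does the effect of any change to the shared core.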